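A few compounds are considered here, and "the series" means these few. Any claim that something is new, unique, unknown or untested is made for them only; others in the source may bear on it.

Compound 1 `CC(=O)NCC#CCn1ccnc1` was tested in a functional assay on the whole organism for agonist activity, with Mus musculus as the target; on this read-out lower numbers stand for an effect already at smaller amounts and higher numbers for an effect only at larger amounts of compound. For compound 1 the assay reported only a limit, > 100 mg/kg. Compound 2 `CC(=O)NCC#CCn1cncc1C` carries methyl in place of hydrogen on an aromatic carbon. For compound 2 the assay again reported only a limit, > 100 mg/kg. The step that the two limits leave unreadable from compound 1 to compound 2 therefore cannot be read. Compound 3 `CCOC(=O)N(C)CC#CCn1ccnc1` has a different core, and the difference between the two cores is not broken down here. For compound 3 the assay also reported only a limit, > 100 mg/kg. Compound 4 `CCOC(=O)N(C)CC#CCn1cncc1C` differs from compound 3 by methyl in place of hydrogen on an aromatic carbon, the same kind of change as before, though here the change sits next to the ring atom that bears a large group rather than a group of 8 heavy atoms. Because (the limit of > 100 mg/kg in this assay, at which 3 of the 3 values shown sit), the step that the limit leaves unreadable from compound 3 to compound 4 is expected to stay unreadable. Compound 4 is estimated at about 150 mg/kg.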

Compound 4, dose for half-maximal effect: 97 mg/kg
Estimate against measurement, compound 4: 1.5-fold (0.19 log units) above, outside the stated range (below it).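

In this assay, methyl in place of hydrogen on an aromatic carbon gives an at least 1.0-fold lower number from compound 3 to compound 4 (0.01 log units; that floor lies within the scatter), so on this core the change yields a number rather than a limit, but that floor does not show a real gain. From the compounds shown here alone, the same change on the core of compound 1 cannot be read, so whether its effect carries from one core to the other stays unknown. Too few values are actual numbers to settle this: the limit of > 100 mg/kg in this assay, at which 3 of the 4 values shown sit.

Still open, going by these compounds, is how this assay would respond on either core to a propyl chain or an amine on that aromatic carbon.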